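Cytotoxicity limits in the biaryl benzamide series

This account rests on a few compounds, and the source may have more. Where it says the series, first, only, none or still open, it means among the compounds named here.

Measured so far in an ADME assay on Raji cells (Homo sapiens) for cytotoxicity, read by CellTiter-Glo and resazurin assay, with a stated time of 72 h; a higher number here means that more compound is needed for the effect, a lower number that less compound is needed:
Compound 1 `CCOC(=O)CCCCCOc1cccc(CN(C(=O)c2ccc(-c3cccc(OCc4ccccc4)c3)cc2)C(C)C)c1` sits at the limit, > 26000 nM.
Compound 2 `CCOC(=O)CCCCCOc1cccc(CN(C(=O)c2ccc(-c3ccc4cc[nH]c4c3)cc2)C(C)C)c1` sits at the limit, > 26000 nM.
Compound 3 `CCOC(=O)CCCCCOc1cccc(CN(C(=O)c2ccc(-c3ccc(Cl)c(Cl)c3)cc2)C(C)C)c1` sits at the limit, > 26000 nM.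

Compound 3 stands where the two others do, at the limit of this assay, so no order among the three can be read. The one step that touches it, a step that the two limits leave unreadable from compound 2 to compound 3, is unreadable for the same reason; all that is shown is the limit of > 26000 nM in this assay, at which 3 of the 3 values shown sit.

Compound 4 `CCOC(=O)CCCCCOc1cccc(CN(C(=O)c2ccc(-c3cccc(Cl)c3)cc2)C(C)C)c1` differs from compound 3 by hydrogen in place of chloro on an aromatic carbon. Within the data shown here, no measured step bears on it with a readable size; the only ground is that every value so far sits at the limit. Compound 4 is therefore expected to stay at or beyond that limit, estimated at 40000 nM (range 15000 nM to 120000 nM), which means an expected step that the limit leaves unreadable from compound 3 to compound 4 that is not read as a change.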

Compound 4, half-maximal effective concentration: > 18400 nM
Compound 4: a limit, no number; the forecaster's own chance of this, stated with the estimate: 85%; the middle value is on the limit's open side.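

In this assay compound 4 gives > 18400 nM, a limit and not a number. Among these compounds, no step from compound 1, compound 2 or compound 3 to compound 4 can be read. The concentration giving the effect for any of these compounds stays open, as does any order among them.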